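This account rests on a few compounds, and the source may have more. Where it says the series, first, only, none or still open, it means among the compounds named here.

In a functional assay on A549 cells (Homo sapiens) for inhibition, read by MTT assay, with a stated time of 72 h (a lower number here means a stronger inhibitor, a higher number a weaker inhibitor), compound 1 (`CC1=NN(c2ccccc2)C(=O)[C@@]12C(=O)C=CC[C@@H]2c1ccccc1[N+](=O)[O-]`) gives 66400 nM, compound 2 (`CC1=NN(c2ccccc2)C(=O)[C@@]12C(=O)C=CC[C@@H]2c1cccc(C)c1`) gives 4510 nM and compound 3 (`COc1ccccc1[C@@H]1CC=CC(=O)[C@]12C(=O)N(c1ccccc1)N=C2C`) gives 3960 nM. Compound 3 thus lies within the scatter of compound 2, and both lie far below compound 1. Compound 4 (`COc1ccccc1[C@H]1CC=CC(=O)[C@@]12C(=O)N(c1ccccc1)N=C2C`) is the untested counterpart of compound 3: the two compounds have the same atoms and bonds and differ only in configuration as drawn: 2 of 2 stereo elements differ (all stereocentres are inverted: mirror images); a stereocentre at a saturated ring carbon is drawn S in compound 3 and R in compound 4; a stereocentre at a saturated ring carbon is drawn S in compound 3 and R in compound 4. Within the data shown here, the only measured step, a 15-fold lower number from compound 1 to compound 2 (1.17 log units; beyond the scatter), is large, but it places 3-methylphenyl in place of 2-nitrophenyl on a saturated ring carbon and leaves configuration untested. Among the measured compounds shown here, no measured pair of mirror images exists, so direction and size remain poorly defined. A modest rise is expected, with the estimated step being a 1.5-fold higher number from compound 3 to compound 4 (0.18 log units; within the scatter). Compound 4 is estimated at 6000 nM, with an expected range of 2000 nM to 25000 nM.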

Compound 4, half-maximal inhibitory concentration: 18700 nM
The estimate for compound 4 lay 3.1-fold (0.49 log units) below the measured number; low and high end bracket the measured number.
By their numbers in this assay, from the lowest: compounds 3 and 2 (each within the scatter of the next); then compound 4; then compound 1.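

In this assay, a 4.7-fold higher number from compound 3 to compound 4 (0.67 log units; beyond the scatter), so configuration alone moves the number beyond the scatter, and the change can be placed there: the fact that compounds 3 and 4 differ only in the configuration as drawn. The standing of the 2-methoxyphenyl group therefore depends on configuration: compound 3 lies within the scatter of compound 2, yet a 4.1-fold higher number from compound 2 to compound 4 (0.62 log units; beyond the scatter). The gain over the nitro compound also persists in compound 4, with a 3.6-fold lower number from compound 1 to compound 4 (0.55 log units; beyond the scatter).

Open, going by these compounds, is whether inverting all stereocentres has a similar effect on compound 1 and compound 2. Also open, on these data alone, is how an amine or a carboxylic acid on the same aromatic ring would read.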